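The compounds below may be only part of what the source reports. "The series", "measured", "known", "first", "only" and "open" are said of these compounds alone.

Measured compounds:
compound 1 `COc1ccc(NC(=O)c2cc(N(C)Cc3ccccc3)ncn2)cc1` — in a physicochemical assay for solubility, using the shake flask method, measured as kinetic solubility, with a stated time of 2 h, at pH 7.4 (on this read-out lower numbers stand for lower solubility and higher numbers for higher solubility), compound 1 gives only a limit of the assay, < 5000 nM
compound 2 `CN(Cc1ccccc1)c1cc(C(=O)Nc2ccccc2)ncn1` — in this assay compound 2 gives only a limit, < 5000 nM
compound 3 `CN(Cc1ccc(F)cc1)c1cc(C(=O)Nc2ccccc2)ncn1` — in this assay compound 3 gives only a limit, < 5000 nM

All three values sit at the same limit, (the limit of < 5000 nM in this assay, at which 3 of the 3 values shown sit), so no number is known for any of them. The change from compound 2 to compound 3 is fluoro in place of hydrogen on an aromatic carbon and its step in this assay is a step that the two limits leave unreadable from compound 2 to compound 3. The core of compound 1 differs from that of compound 2 by methoxy in place of hydrogen on an aromatic carbon, with the step that the two limits leave unreadable from compound 1 to compound 2, again unreadable from the two limits.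

Compound 4 `COc1ccc(NC(=O)c2cc(N(C)Cc3cccc(F)c3)ncn2)cc1` is not yet measured. It differs from compound 1 by fluoro in place of hydrogen on an aromatic carbon. This is the same kind of change as that from compound 2 to compound 3, not the same: in compound 3 the fluoro sits para to a large group, in compound 4 meta to a large group.

For compound 1 to compound 4 a step that the limit leaves unreadable from compound 1 to compound 4 is expected, resting on the observation that the like change from compound 2 to compound 3 gave a step that the two limits leave unreadable from compound 2 to compound 3 and that all three measured values sit at the limit. Compound 4 is estimated at 2500 nM, between 400 nM and 6000 nM, most probably reported as a limit again.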

Compound 4, solubility: 5000 nM
For compound 4 the middle estimate is 2.0-fold (0.30 log units) below the measured one, and the stated range covers the measured number.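

In this assay the change from benzyl to 3-fluorobenzyl on the core of compound 1 reads as a number no lower from compound 1 to compound 4 (the limit leaves the size open), and compound 4 gives a number, 5000 nM. Compound 1 gives only a limit, < 5000 nM, so this does not show how large the step is or whether there is any rise at all. The other steps cannot be read, including the fluoro change on the core of compound 2, where the fluoro also sits in a different place, so carrying the change from one core to another is neither supported nor contradicted, and the series remains mostly unresolved at this read-out: the limit of < 5000 nM in this assay, at which 3 of the 4 values shown sit.

Still open, going by these compounds, is whether a 3-fluorobenzyl group on the core of compound 2 would give a number as it does in compound 4. Also open, on these data alone, is whether an amine or a carboxylic acid on the benzyl group, or a longer chain in place of the methyl on the nitrogen, would give values clear of the limit.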